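Amide variation on a shared core: cytotoxicity notes

The compounds below may be only part of what the source reports. "The series", "measured", "known", "first", "only" and "open" are said of these compounds alone.

The series keeps one core and varies the group on the carbonyl carbon of the amide. Compound 1 `COc1ccc(-c2cnc(NC(=O)C3CCCCC3)n2C)cc1` carries cyclohexyl there; in a toxicity assay on THP-1 cells (Homo sapiens) for inhibition (on this read-out higher numbers stand for lower toxicity in this test and lower numbers for higher toxicity in this test), compound 1 gives > 100000 nM, a limit of the assay and not a number. Compound 2 `COc1ccc(-c2cnc(NC(=O)c3ccco3)n2C)cc1` carries furan-2-yl; in this assay compound 2 gives > 100000 nM, again a limit. Compound 3 `COc1ccc(-c2cnc(NC(=O)c3ccn[nH]3)n2C)cc1` carries 1H-pyrazol-5-yl; in this assay compound 3 gives > 100000 nM, also a limit. Compound 3 thus stands at the top of the window, where all three measured compounds sit (the limit of > 100000 nM in this assay, at which 3 of the 3 values shown sit).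

The measured steps are a step that the two limits leave unreadable from compound 1 to compound 2, a step that the two limits leave unreadable from compound 1 to compound 3 and a step that the two limits leave unreadable from compound 2 to compound 3; none of them can be sized, because (the limit of > 100000 nM in this assay, at which 3 of the 3 values shown sit) both ends of each step rest on the limit.

Compound 4 `COc1ccc(-c2cnc(NC(=O)CCc3ccccc3)n2C)cc1` is not yet measured. It differs from compound 3 by phenethyl in place of 1H-pyrazol-5-yl on a carbonyl carbon. Every change of the group on the carbonyl carbon seen so far, from cyclohexyl through furan-2-yl to 1H-pyrazol-5-yl, has left the read-out at the limit, so no step beyond the scatter is expected in this assay for this exchange either; the expected step is a number no higher from compound 3 to compound 4 (the limit leaves the size open). Compound 4 is therefore estimated at 100000 nM, within 30000 nM to 300000 nM, most likely reported again as a limit.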

Compound 4, half-maximal cytotoxic concentration: > 100000 nM
Compound 4 was reported as a limit; the forecaster's own chance of this, stated with the estimate: 75%; the middle value lies on the limit itself.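

Compound 4 joins compound 1, compound 2 and compound 3 at a limit in this assay, so no step from any of them to compound 4 can be read: the limit of > 100000 nM in this assay, at which 4 of the 4 values shown sit.

The compounds shown leave open at what concentration any of the four would reach half-maximal cytotoxicity, and whether any group on the carbonyl carbon changes it.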